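This account rests on a few compounds, and the source may have more. Where it says the series, first, only, none or still open, it means among the compounds named here.

Measured so far in a functional assay on cells (Cancer cell lines, Homo sapiens) for cytotoxicity, read by sulforhodamine B assay, with a stated time of 48 h; on this read-out lower numbers stand for stronger inhibition of growth and higher numbers for weaker inhibition of growth:
- compound 1 `NS(=O)(=O)c1ccc(-n2nc(-c3ccc(Cl)cc3)cc2-c2cc(O)ccc2O)cc1` gives 29800 nM
- compound 2 `CC(=O)NS(=O)(=O)c1ccc(-n2nc(-c3ccccc3)cc2-c2cc(O)ccc2O)cc1` gives 100000 nM

Going by the values given here, compound 2 stands at the highest of the two numbers in this assay; compound 1, the only neighbour, sits at a clearly lower number, and the gap between the two values is beyond the usual scatter. Among the compounds with values here, no single-point step links them, since compound 1 and compound 2 differ in more than one place, so the two values are simply noted side by side and nothing is drawn from the pair about either change on its own.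

Compound 3 `CC(=O)NS(=O)(=O)c1ccc(-n2nc(-c3ccc(Cl)cc3)cc2-c2cc(O)ccc2O)cc1` has not been measured. It takes compound 2 and makes one change: chloro in place of hydrogen on an aromatic carbon. Compound 3 is thus the acetylated counterpart of compound 1.

For compound 3 in this assay a step downward from compound 2 is expected, of moderate size, a 2.0-fold lower number from compound 2 to compound 3 (0.30 log units; within the scatter), since compound 1, which also carries the chloro group, gives 29800 nM. Compound 3 is therefore estimated at 50000 nM, within a range from 20000 nM to 100000 nM.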

Compound 3, concentration for total growth inhibition: 38800 nM
Beside the measured number, compound 3's estimate is 1.3-fold (0.11 log units) above it; the measured number falls inside the stated range.
By their numbers in this assay, from the lowest: compounds 1 and 3 (each within the scatter of the next); then compound 2.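

In this assay the chloro group on an aromatic carbon, para to a large group, now has a reading of its own, with the acetyl on the sulfonamide nitrogen held constant: the series shows a 2.6-fold lower number from compound 2 to compound 3 (0.41 log units; beyond the scatter), a modest step for phenyl to 4-chlorophenyl. The sulfonamide nitrogen also gains a one-place comparison: with 4-chlorophenyl held constant, the series shows a 1.3-fold higher number from compound 1 to compound 3 (0.11 log units; within the scatter), so acetyl and hydrogen at this nitrogen cannot be told apart in this read-out. Nothing available gives a reason for either step.

The chloro step is shown only with the acetyl on the sulfonamide nitrogen and the acetyl comparison only with 4-chlorophenyl, so whether either holds with the other group changed remains open. Also open, from the compounds shown here alone, is whether fluoro, bromo or methoxy at the same aromatic carbon, or a propionyl group or longer acyl chain on the sulfonamide nitrogen, would give a step of similar size.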